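The source may report more compounds than this note shows. Statements on the series, on what has been measured and on what is new or still open speak of the compounds shown alone.

Measured compounds:
- compound 1, `CCN(CC)Cc1ccc(S(=O)(=O)NCc2ccc(CNC(=O)c3ccc(F)cc3)cc2)cc1`, gives 1 nM in an assay on MDA-MB-231 cells for binding affinity to C-X-C chemokine receptor type 4 (Homo sapiens), read by fluorescence and microscopy, with stated times of 10 min and 30 min; a lower number here means that less compound is needed, a higher number that more compound is needed for the effect
- compound 2, `O=C(NCc1ccc(CNS(=O)(=O)c2cccc(C(F)(F)F)c2)cc1)c1ccc(F)cc1`, gives 100 nM in this assay

Of these two numbers, compound 2 has the highest. Its nearest neighbour, compound 1, sits at a far lower number, and that gap is well beyond the usual scatter of such measurements.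

Compound 3, `O=C(NCc1ccc(CNS(=O)(=O)c2ccc([N+](=O)[O-])cc2)cc1)c1ccc(F)cc1`, has not yet been measured. It differs from compound 2 in one place: 4-nitrophenyl in place of 3-(trifluoromethyl)phenyl on a sulfonyl sulfur. Among the compounds with values here, no pair of measured compounds isolates this exact change, so any expectation for compound 3 rests on compound 2 alone, with no measured step to lean on.

In this assay a modest move toward a lower number is expected, of a size that may or may not clear the scatter. The expected step is a 1.7-fold lower number from compound 2 to compound 3 (0.22 log units; within the scatter). Compound 3 is estimated at 60 nM, with a likely range from 10 nM to 400 nM.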

Compound 3, effective concentration (reported as EC, without a stated level of effect): 1000 nM
Beside the measured number, compound 3's estimate is 17-fold (1.22 log units) below it; the measured number lies above the stated range.
By their numbers in this assay, from the lowest: compound 1; then compound 2; then compound 3.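

In this assay, 4-nitrophenyl in place of 3-(trifluoromethyl)phenyl on a sulfonyl sulfur gives a 10-fold higher number from compound 2 to compound 3 (1.00 log units; beyond the scatter), so the choice between these two aryl groups clearly matters, even though neither carries an amine. Nitro in place of (diethylamino)methyl on an aromatic carbon gives a 1000-fold higher number from compound 1 to compound 3 (3.00 log units; beyond the scatter), the larger of the two steps and the first measured one that involves the (diethylamino)methyl group. Nothing available explains either step.

From the compounds shown here alone, the first swap alters both the group and its ring number, so the effect of each alone remains unknown. Going by these compounds, it also remains open whether the diethylamino part matters specifically, or whether a simpler aminomethyl group or a carboxylic acid at that ring carbon would give a low or a high number.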